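One Amine Swap Carried to a Second Core

This account rests on a few compounds, and the source may have more. Where it says the series, first, only, none or still open, it means among the compounds named here.

Compound 1 `CCNCC(=O)Nc1cc(OC)ccc1C(=O)c1cc(OC)c(OC)c(OC)c1` and compound 2 `COc1ccc(C(=O)c2cc(OC)c(OC)c(OC)c2)c(NC(=O)CN(C)C)c1` share a core and differ only in the amide chain. In a functional assay on A2780 cells (Homo sapiens) for antiproliferative activity, read by MTT assay, with a stated time of 48 h (on this read-out higher numbers stand for weaker inhibition and lower numbers for stronger inhibition), compound 1 gives 950 nM, and compound 2 gives 580 nM. The change between them is dimethylamino in place of ethylamino on a saturated chain carbon bound to a carbonyl carbon, and the step it made is a 1.6-fold lower number from compound 1 to compound 2 (0.21 log units; within the scatter).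

Compound 3 `C=C(c1ccc(OC)cc1NC(=O)CNCC)c1ccc(OC)c2c1OC(C)(C)C=C2` is built on a different core; the difference between the two cores is not broken down here. In this assay compound 3 gives 1030 nM, a number that lies within the scatter of compound 1 and of compound 2, so no order among the three compounds can be read from these values.

Compound 4 `C=C(c1ccc(OC)cc1NC(=O)CN(C)C)c1ccc(OC)c2c1OC(C)(C)C=C2` carries the same change on the core of compound 3: dimethylamino in place of ethylamino on a saturated chain carbon bound to a carbonyl carbon. The place is described in the same words in both pairs, so this is the same change, and it occurs in two pairs among the compounds shown.

Among the measured compounds shown here, the only guide to the outcome is the earlier pair, in which the change moved the number a little and within the scatter. Compound 4 is expected to come out with a step of about a 1.6-fold lower number from compound 3 to compound 4 (0.20 log units; within the scatter), an expectation that rests on compound 1 and compound 2 through a 1.6-fold lower number from compound 1 to compound 2 (0.21 log units; within the scatter) alone. The estimate for compound 4 in this assay is 650 nM, with a range from 350 nM to 1300 nM.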

Compound 4, half-maximal inhibitory concentration: 420 nM
Compound 4: middle estimate off by 1.5-fold (0.19 log units), on the high side; measured number inside the range.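

In this assay, among the compounds shown here, dimethylamino in place of ethylamino on the second core gave a 2.5-fold lower number from compound 3 to compound 4 (0.39 log units; beyond the scatter), a modest step, and the first one on this change that stands clear of the scatter. Set beside the earlier step, it does not differ in size by more than repeated measurement would allow: the same change on two cores in this assay, a 1.6-fold lower number (0.21 log units; within the scatter) from compound 1 to compound 2 and a 2.5-fold lower number (0.39 log units; beyond the scatter) from compound 3 to compound 4, 1.5-fold (0.18 log units) apart, within the scatter of two such steps. The change can therefore be carried from one core to the other with no measurable difference in the size of its step, but this does not show that the second core responds more strongly, and two pairs set no rule for any further core.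

The compounds shown leave open how other amines on the same amide chain would behave, such as diethylamino or a cyclic amine, and whether a longer chain carrying the amine would give a step of similar size. They also leave open whether the change would give a comparable step on a third core, and what lies behind the step at all, which these numbers alone cannot tell.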